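Changing the Aryl Group on the Amide Nitrogen

The source may report more compounds than this note shows. Statements on the series, on what has been measured and on what is new or still open speak of the compounds shown alone.

Compound 2 `O=C(Cn1c(=O)c(/C=C\c2ccncc2)nc2ccccc21)Nc1ccc(Cl)cc1` carries a 4-chlorophenyl group on an amide-type nitrogen whose other neighbour is a carbonyl carbon. In a functional assay on K562 cells (Homo sapiens) for inhibition, read by MTT assay, with a stated time of 24 h (on this read-out lower numbers stand for stronger inhibition and higher numbers for weaker inhibition), compound 2 gives only a limit, > 50400 nM, and no number. Its relative compound 1 `O=C(Cn1c(=O)c(/C=C\c2ccncc2)nc2ccccc21)Nc1ccc(F)cc1` has fluoro in place of chloro on an aromatic carbon. In this assay compound 1 also gives only a limit, > 100000 nM. The step that the two limits leave unreadable from compound 1 to compound 2 therefore cannot be read; this follows from the limit of > 100000 nM in this assay, at which 1 of the 2 values shown sits, and (the limit of > 50400 nM in this assay, at which 1 of the 2 values shown sits).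

Compound 3 `Cc1ccccc1NC(=O)Cn1c(=O)c(/C=C\c2ccncc2)nc2ccccc21` alters the ring on that nitrogen: 2-methylphenyl in place of 4-chlorophenyl on an amide-type nitrogen. Within the data shown here, no measured step bears directly on this change, and the single known step is itself unreadable, so the guidance is thin. The expected step that the limit leaves unreadable from compound 2 to compound 3 is none beyond the scatter. Compound 3 is expected to give about 80000 nM, within a range from 20000 nM to 300000 nM.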

Compound 3, half-maximal inhibitory concentration: > 100000 nM
Compound 3 ended at the assay's limit; the forecaster's own chance of this, stated with the estimate: 75%; at least 1.2-fold (0.09 log units) between middle value and limit.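

Among these compounds, no step among compound 1, compound 2 and compound 3 can be read in this assay, because each of the three gives only a limit and no number: the limit of > 100000 nM in this assay, at which 2 of the 3 values shown sit.

The compounds shown leave open whether changing the aryl group on the amide-type nitrogen moves the value in this assay at all.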